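Nitro in Place of Fluoro on the Benzyl Ring

This account rests on a few compounds, and the source may have more. Where it says the series, first, only, none or still open, it means among the compounds named here.

Of the compounds shown here, three sharing one core have so far been measured in an ADME assay on MRC5 cells (Homo sapiens) for cytotoxicity; a lower number here means a stronger inhibitor, a higher number a weaker inhibitor. Compound 1 `COc1ccc(Cn2cc(CNC(=O)c3ccc([N+](=O)[O-])o3)nn2)cc1F` gives 324000 nM, the highest of the three numbers. Compound 2 `O=C(NCc1cn(Cc2ccc([N+](=O)[O-])cc2)nn1)c1ccc([N+](=O)[O-])o1` gives 213000 nM, and compound 3 `COc1cc(Cn2cc(CNC(=O)c3ccc([N+](=O)[O-])o3)nn2)ccc1F` gives 155000 nM. The step of a 1.5-fold lower number from compound 1 to compound 2 (0.18 log units; within the scatter) stays within the scatter, the step of a 2.1-fold lower number from compound 1 to compound 3 (0.32 log units; beyond the scatter) is modest but beyond it, and the step of a 1.4-fold lower number from compound 2 to compound 3 (0.14 log units; within the scatter) is again within it.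

Compound 4 `COc1ccc(Cn2cc(CNC(=O)c3ccc([N+](=O)[O-])o3)nn2)cc1[N+](=O)[O-]` has not yet been measured in this assay. It differs from compound 1 in one place: nitro in place of fluoro on an aromatic carbon. The nearest comparison is the step from compound 1 to compound 2, which also introduces a nitro group onto the phenyl ring and remains within the scatter; the step to compound 3, which only rearranges fluoro and methoxy, is modest. On that basis the change to compound 4 is expected to produce no step beyond the scatter in this assay, and the estimated step is a 1.3-fold lower number from compound 1 to compound 4 (0.11 log units; within the scatter). Compound 4 is therefore expected to give 250000 nM, with a range from 120000 nM to 500000 nM.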

Compound 4, half-maximal inhibitory concentration: 198000 nM
Beside the measured number, compound 4's estimate is 1.3-fold (0.10 log units) above it; low and high end bracket the measured number.
By their numbers in this assay, from the lowest: compounds 3, 4, 2 and 1 (each within the scatter of the next, the first and the last beyond it).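

In this assay, nitro in place of fluoro on the aromatic carbon ortho to a methoxy group gives a 1.6-fold lower number from compound 1 to compound 4 (0.21 log units; within the scatter) and so stays within the scatter, even though three heavy atoms replace one at this position. Among these compounds, the earlier steps exchanged the whole substituted phenyl group, whereas this change keeps the methoxy group and alters only the one substituent, so it reads this position on its own. Nothing available here explains the size of this step.

The compounds shown leave open whether an amine or a carboxylic acid at this position would also stay within the scatter of compound 1. They also leave open whether a longer chain in place of the methoxy group would change how this position responds.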